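A chloro group added to compound 2

The source may report more compounds than this note shows. Statements on the series, on what has been measured and on what is new or still open speak of the compounds shown alone.

In a functional assay on HO8910 cells (Homo sapiens) for inhibition, read by MTT assay, with a stated time of 24 h, tested at 1 ug/mL (on this read-out lower numbers stand for less inhibition of growth and higher numbers for more inhibition of growth at the one concentration tested), compound 1 (`O=C(CCCCC1CCSS1)Nc1ccc(OC(F)(F)F)cc1`) gives 10% and compound 2 (`O=C(CCCCC(CCSC(=O)c1ccccc1)SC(=O)c1ccccc1)Nc1ccccc1`) gives 3.79% so the two stand within the usual scatter of each other. Compound 3 (`O=C(CCCCC(CCSC(=O)c1ccccc1)SC(=O)c1ccccc1)Nc1cccc(Cl)c1`) differs from compound 2 by one change: chloro in place of hydrogen on an aromatic carbon with chloro in place of hydrogen on an aromatic carbon, meta to a large group. For the measured compounds named here, no measured step shows what this change does, so no shift beyond the scatter is expected in this assay in either direction. The expected change is a number 3.2 percentage points higher from compound 2 to compound 3 (within the scatter) and lies within the scatter. Compound 3 is estimated at 7% with an expected range from 1% to 18% in this read-out.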

Compound 3, percent growth inhibition at one concentration: 3.38%
For compound 3 the middle estimate is 3.6 percentage points above the measured one; measured number inside the range.
By their numbers in this assay, from the lowest: compounds 3, 2 and 1 (each within the scatter of the next).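

In this assay, for the compounds shown here, chloro in place of hydrogen on an aromatic carbon, meta to a large group, gives a number 0.4 percentage points lower from compound 2 to compound 3 (within the scatter), the first reading of any change at this position. The step from phenyl to 3-chlorophenyl therefore does not separate the two compounds at the one concentration tested. No measured information bears on this result.

As far as these compounds go, whether an amine or a carboxylic acid at this position would move the number beyond the scatter remains open. So does the effect of chloro elsewhere on the same ring.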